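Swapping bromo for methyl on the aryl ring of compound 2

This account rests on a few compounds, and the source may have more. Where it says the series, first, only, none or still open, it means among the compounds named here.

Measured so far:
Compound 1, `CCCCCCCCCCCCCCCCCCNC(=O)[C@H]1CSC(C2CCCCC2)N1`: 12800 nM
Compound 2, `CCCCCCCCCCCCCCCCCCNC(=O)[C@H]1CSC(c2ccc(Br)cc2)N1`: 5100 nM

Two compounds share one core and differ only in the group on a saturated ring carbon. In a functional assay on LNCaP cells (Prostate gland, Homo sapiens) for antiproliferative activity, read by sulforhodamine B assay (a higher number here means a weaker inhibitor, a lower number a stronger inhibitor), compound 1 gives 12800 nM, and compound 2 gives 5100 nM. Among the compounds with values here, the one step measured, a 2.5-fold lower number from compound 1 to compound 2 (0.40 log units; beyond the scatter), came with 4-bromophenyl in place of cyclohexyl. Within the data shown here, compound 2 therefore stands at the lowest of the two numbers, with compound 1 the only neighbour.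

Compound 3, `CCCCCCCCCCCCCCCCCCNC(=O)[C@H]1CSC(c2ccc(C)cc2)N1`, is not yet measured. It differs from compound 2 in this way: methyl in place of bromo on an aromatic carbon. Among the measured compounds shown here, the only measured step does not bear directly on this change, since it replaced the whole cyclohexyl with an aryl ring rather than trading one small group for another on that ring. For the measured compounds named here, with no step on the aryl group itself to lean on, the expectation is a change of no more than the scatter in this assay, with compound 3 expected to land close to compound 2, as a 1.3-fold higher number from compound 2 to compound 3 (0.11 log units; within the scatter). The estimate for compound 3 is therefore 6500 nM, within a range from 2500 nM to 17000 nM.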

Compound 3, half-maximal inhibitory concentration: 1900 nM
Compound 3: middle estimate off by 3.4-fold (0.53 log units), on the high side, and the stated range ends above it.
By their numbers in this assay, from the lowest: compound 3; then compound 2; then compound 1.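

In this assay, the small group on the aryl ring turns out to matter: methyl in place of bromo, on an aromatic carbon para to a large group, gives a 2.7-fold lower number from compound 2 to compound 3 (0.43 log units; beyond the scatter) and so lies beyond the usual scatter, even though each group counts a single heavy atom and neither adds a hydrogen-bond donor or acceptor. Within the data shown here, the earlier pair showed only that a 4-bromophenyl group could stand in for cyclohexyl, whereas 4-methylphenyl in that place gives a 6.7-fold lower number from compound 1 to compound 3 (0.83 log units; beyond the scatter) in the same assay, so the size of the step away from cyclohexyl depends on what the aryl ring carries. No measurement is available that explains why methyl gives the lower number here.

Among these compounds, with only two groups compared on the aryl ring, it remains open whether a chloro, a methoxy or an amine in the same place would read closer to methyl or to bromo. As far as these compounds go, it is also open whether methyl would still give the lower number than bromo with a shorter chain on the amide nitrogen in place of the long one.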